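Swapping the amide side chain for 2-hydroxyethoxy

The source may report more compounds than this note shows. Statements on the series, on what has been measured and on what is new or still open speak of the compounds shown alone.

In an ADME assay on Raji cells (Homo sapiens) for cytotoxicity, read by luminescence, with a stated time of 72 h (on this read-out higher numbers stand for an effect only at larger amounts of compound and lower numbers for an effect already at smaller amounts), compound 1 `CCOC(=O)c1c(-c2cc(F)cc(OC)c2)[nH]c2cc(OC)c(F)cc2c1=O` gives > 21500 nM as a limit and not a number. Compound 2 `COc1cc2[nH]c(-c3cccc(Oc4ccccc4)c3)c(C(=O)NCCN3CCCC3)c(=O)c2cc1F` gives > 21500 nM, again a limit. Compound 3 `COc1cc2[nH]c(-c3cccc(Oc4ccccc4)c3)c(C(=O)NCCCN3CCCC3)c(=O)c2cc1F` gives > 21500 nM, also a limit, so its position is bounded on one side only. Compound 4 `COc1cc2[nH]c(-c3cccc(Oc4ccccc4)c3)c(C(=O)OCCO)c(=O)c2cc1F` carries 2-hydroxyethoxy in place of (3-(pyrrolidin-1-yl)propyl)amino on a carbonyl carbon. Going by the values given here, the one measured step is a step that the two limits leave unreadable from compound 2 to compound 3 and offers no size to carry over. The expectation therefore rests on the limit of > 21500 nM in this assay, at which 3 of the 3 values shown sit, alone. The expected change in this assay is a step that the limit leaves unreadable from compound 3 to compound 4 and nothing beyond the scatter, with no direction expected. For compound 4 the estimate is 25000 nM, with an expected range of 9000 nM to 60000 nM and another limit as the likeliest report.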

Compound 4, half-maximal effective concentration: > 21500 nM
Compound 4 was reported as a limit; the forecaster's own chance of this, stated with the estimate: 80%; the middle value does not contradict the limit.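

Compound 4 is reported only as a limit, as are compound 2 and compound 3, so neither step into compound 4 can be read. The compounds shown leave open whether 2-hydroxyethoxy in place of either amino side chain changes the result in this assay.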